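Switching the anilino ring from compound 3 to compound 4

The source may hold more compounds than are shown below. What is called first, only, known or untested is meant among the compounds shown, and "the series" means these compounds.

Compound 3 `C=CC(=O)Nc1cccc(NC(=O)CSc2nc(Nc3ccccc3Cl)c3ccccc3n2)c1` stands second highest of the three numbers in a functional assay on MGC-803 cells (Homo sapiens) for inhibition, read by MTT assay, with a stated time of 72 h (a higher number here means a weaker inhibitor, a lower number a stronger inhibitor), where compound 3 gives 20700 nM. Compound 1 `O=C(CSc1nc(Nc2ccccc2)c2ccccc2n1)Nc1ccccc1Cl` gives 24800 nM in this assay, and compound 2 `O=C(CSc1nc(Nc2ccccc2)c2ccccc2n1)Nc1ccc(C(F)(F)F)cc1` gives 8670 nM; the gap from compound 3 to compound 1 lies within the scatter, while compound 2 sits below both. Compound 4 `C=CC(=O)Nc1cccc(NC(=O)CSc2nc(Nc3ccc(Br)cc3)c3ccccc3n2)c1` differs from compound 3 by 4-bromophenyl in place of 2-chlorophenyl on a nitrogen on an aromatic ring. For the measured compounds named here, the one measured step that bears on it is a 2.9-fold lower number from compound 1 to compound 2 (0.46 log units; beyond the scatter), which exchanged a 2-chlorophenyl group at a different place in the molecule. By loose analogy, a modest lowering is expected for compound 4, so its step of a 1.5-fold lower number from compound 3 to compound 4 (0.17 log units; within the scatter) is estimated to be small. Compound 4 is therefore estimated at 14000 nM, with a range from 6000 nM to 35000 nM.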

Compound 4, half-maximal inhibitory concentration: 11500 nM
The estimate for compound 4 lay 1.2-fold (0.09 log units) above the measured number, within the range that was stated.
By their numbers in this assay, from the lowest: compounds 2, 4, 3 and 1 (each within the scatter of the next, the first and the last beyond it).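

In this assay, 4-bromophenyl in place of 2-chlorophenyl on a nitrogen on an aromatic ring gives a 1.8-fold lower number from compound 3 to compound 4 (0.26 log units; within the scatter), so this position accepts the exchange with no difference that stands clear of the scatter. For the compounds shown here, the earlier step concerned the amide-type nitrogen, and this is the first reading at the other nitrogen. No measurement shown here accounts for this result. The step alters both the halogen and its place, and these cannot be separated. As far as these compounds go, whether an amine or a carboxylic acid on this ring would shift the number stays open.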